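From 4-fluorobenzyl to benzoylmethyl on the sulfur

The compounds below may be only part of what the source reports. "The series", "measured", "known", "first", "only" and "open" are said of these compounds alone.

Compound 1 `COc1cc(-c2nnc(S)n2-c2ccc(N(C)C)cc2)cc(OC)c1OC`: > 60000 nM, a limit
Compound 2 `COc1cc(-c2nnc(SCc3ccccc3)n2-c2ccc(N(C)C)cc2)cc(OC)c1OC`: > 60000 nM, a limit
Compound 3 `COc1cc(-c2nnc(SCc3ccc(F)cc3)n2-c2ccc(N(C)C)cc2)cc(OC)c1OC`: 26400 nM

All three compounds were tested in a functional assay on HepG2 cells (Homo sapiens) for inhibition, read by MTT assay, with a stated time of 48 h; on this read-out higher numbers stand for weaker inhibition and lower numbers for stronger inhibition. Compound 3 alone has a number there, while the other two sit at the limit of > 60000 nM in this assay, at which 2 of the 3 values shown sit. Compound 4 `COc1cc(-c2nnc(SCC(=O)c3ccccc3)n2-c2ccc(N(C)C)cc2)cc(OC)c1OC` differs from compound 3 as follows: benzoyl in place of 4-fluorophenyl on a saturated chain carbon bound to a sulfur. The 4-fluorobenzyl in place of hydrogen on a sulfur gave an at least 2.2-fold lower number from compound 1 to compound 3 (0.35 log units; beyond the scatter). The fluoro in place of hydrogen on an aromatic carbon gave an at least 2.2-fold lower number from compound 2 to compound 3 (0.35 log units; beyond the scatter). Among the compounds with values here, compound 4 has no fluoro, so part of that gain may be lost, though no measured step covers the entering benzoyl. The expected step is small and toward weaker inhibition: a 1.5-fold higher number from compound 3 to compound 4 (0.18 log units; within the scatter). Compound 4 is estimated at 40000 nM, with an expected range from 14000 nM to 90000 nM.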

Compound 4, half-maximal inhibitory concentration: 18900 nM
Compound 4: the middle estimate sits 2.1-fold (0.33 log units) above what was measured; low and high end bracket the measured number.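

In this assay, benzoylmethyl on the sulfur does no differently from 4-fluorobenzyl, with a 1.4-fold lower number from compound 3 to compound 4 (0.15 log units; within the scatter). Compound 4 thus shows that a group with a carbonyl and no fluoro also gives a measured number at this position, with an at least 3.1-fold lower number from compound 2 to compound 4 (0.50 log units; beyond the scatter) and with an at least 3.1-fold lower number from compound 1 to compound 4 (0.50 log units; beyond the scatter). These last two steps start from limits and are bounds only: the limit of > 60000 nM in this assay, at which 2 of the 4 values shown sit.

The compounds shown leave open whether an amine or a carboxylic acid in place of the benzoyl would hold this level. They also leave open what a longer chain on the sulfur, or a fluoro on the benzoyl, would do.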